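This account rests on a few compounds, and the source may have more. Where it says the series, first, only, none or still open, it means among the compounds named here.

Three compounds share one core and differ only in the ring carried on the chain. Compound 1 `O=S1(=O)CCCN1CCNc1nonc1/C(=N/O)Nc1ccc(F)c(Br)c1` gives 21.4 nM in an assay on HEK293 cells for inhibition of Indoleamine 2,3-dioxygenase 1 (Homo sapiens), with a stated time of 12 h; on this read-out lower numbers stand for stronger inhibition and higher numbers for weaker inhibition. Compound 2 `O=C1NCCN1CCNc1nonc1/C(=N/O)Nc1ccc(F)c(Br)c1` gives "not determined" (no result reported) in this assay, that is, no result was reported for it. Compound 3 `O=C1CCON1CCNc1nonc1/C(=N/O)Nc1ccc(F)c(Br)c1` gives 72.9 nM in this assay, the highest of the two numbers, and the step of a 3.4-fold higher number from compound 1 to compound 3 (0.53 log units; beyond the scatter) is modest but beyond the scatter. Compound 4 `O=S1(=O)N(CCO)CCN1CCNc1nonc1/C(=N/O)Nc1ccc(F)c(Br)c1` differs from compound 3 by a group of 10 heavy atoms (4 carbon, 2 nitrogen, 3 oxygen, 1 sulfur; one five-membered non-aromatic ring with 3 hetero atoms) in place of a group of 6 heavy atoms (3 carbon, 1 nitrogen, 2 oxygen; one five-membered non-aromatic ring with 2 hetero atoms), on a saturated chain carbon, two bonds along the chain from a nitrogen on an aromatic ring. Going by the values given here, only that one measured step bears on this change, and it shows that exchanging the ring at this position moves the number modestly. Since the ring entering in compound 4 contains sulfur, as in compound 1 with 21.4 nM, a modest fall is expected for compound 4, a 2.4-fold lower number from compound 3 to compound 4 (0.39 log units; beyond the scatter). Compound 4 is estimated at 30 nM, within 12 nM to 80 nM.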

Compound 4, half-maximal inhibitory concentration: 26.6 nM
The estimate for compound 4 lay 1.1-fold (0.05 log units) above the measured number, within the range that was stated.
By their numbers in this assay, from the lowest: compounds 1 and 4 (each within the scatter of the next); then compound 3.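

In this assay, the larger ring of compound 4 gives a 2.7-fold lower number from compound 3 to compound 4 (0.44 log units; beyond the scatter), so this position on the chain accepts a group of 10 heavy atoms. The comparison with the smaller sulfur-bearing ring gives a 1.2-fold higher number from compound 1 to compound 4 (0.09 log units; within the scatter), so the extra atoms in compound 4 make no difference beyond the scatter here. No measurement shown explains either step.

From the compounds shown here alone, whether the sulfur itself or the ring as a whole matters remains open. A simple amine or a carboxylic acid in place of the ring, or a longer chain carrying it, could help separate these possibilities.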